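Methyl on the aryl ether ring: compound 3 to compound 4

The compounds below may be only part of what the source reports. "The series", "measured", "known", "first", "only" and "open" are said of these compounds alone.

Measured so far:
- compound 1, `O=C(O)CCNC(=O)c1ccc(C(Oc2ccc(-n3cc(C(F)(F)F)cn3)cc2)C2CC2)cc1`, gives 1300 nM in an assay on cells for displacement of a labelled ligand from Glucagon receptor (Homo sapiens), in the presence of a further agent that is not named here; on this read-out higher numbers stand for weaker inhibition and lower numbers for stronger inhibition
- compound 2, `CCCC(Oc1ccc(-n2cc(F)cn2)cc1)c1ccc(C(=O)NCCC(=O)O)cc1`, gives 1700 nM in this assay
- compound 3, `CCCC(Oc1ccc(-n2cc(C(F)(F)F)cn2)cc1)c1ccc(C(=O)NCCC(=O)O)cc1`, gives 890 nM in this assay

Compound 3 has the lowest of the three numbers, but both of its steps to the others lie within the scatter: a 1.5-fold lower number from compound 1 to compound 3 (0.16 log units; within the scatter), and a 1.9-fold lower number from compound 2 to compound 3 (0.28 log units; within the scatter). For the measured compounds named here, on these three numbers no compound can be called stronger or weaker than another.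

Compound 4, `CCCC(Oc1ccc(-n2cc(C(F)(F)F)cn2)c(C)c1)c1ccc(C(=O)NCCC(=O)O)cc1`, differs from compound 3 by methyl in place of hydrogen on an aromatic carbon. Neither measured step is of this kind: one exchanges the chain on the ether carbon, the other the substituent on the pyrazole. Going by the values given here, both were within the scatter, and that is the only information available on how small changes near the ether oxygen are tolerated. Among the compounds with values here, there is no measured pair that adds a group to the aryl ether ring itself, so the expectation for compound 4 rests on compound 3 alone.

No step beyond the scatter is expected; the estimated step is a 1.0-fold higher number from compound 3 to compound 4 (0.00 log units; within the scatter). Compound 4 is therefore expected to give about 900 nM in this assay, with a range of 300 nM to 2700 nM.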

Compound 4, inhibition constant: 200 nM
Compound 4: the middle estimate sits 4.5-fold (0.65 log units) above what was measured; measured number below the stated range.
By their numbers in this assay, from the lowest: compound 4; then compounds 3, 1 and 2 (each within the scatter of the next).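

Methyl in place of hydrogen on an aromatic carbon, ortho to a 4-(trifluoromethyl)-1H-pyrazol-1-yl group, gives a 4.5-fold lower number from compound 3 to compound 4 (0.65 log units; beyond the scatter) in this assay, so adding one carbon at this position moves the number beyond the scatter. For the compounds shown here, the two earlier changes, on the chain at the ether carbon and on the pyrazole, gave a 1.5-fold lower number from compound 1 to compound 3 (0.16 log units; within the scatter) and a 1.9-fold lower number from compound 2 to compound 3 (0.28 log units; within the scatter), so among the places varied in these compounds, this ring position is the only one with a step beyond the scatter. Nothing at hand bears on why this methyl has this effect.

The compounds shown leave open whether this step is particular to methyl or is shared by a chloro, ethyl or methoxy group on the same carbon, and whether a methyl on another carbon of this ring would do the same. Going by these compounds, it also remains open whether the same methyl would give a similar step with the cyclopropyl group of compound 1 or the fluoro group of compound 2 in place of the propyl chain and trifluoromethyl group of compound 3.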